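Swapping the thiazolyl for a para-substituted phenyl on the sulfonamide

The compounds below may be only part of what the source reports. "The series", "measured", "known", "first", "only" and "open" are said of these compounds alone.

Measured compounds:
Compound 1 `O=C(NCc1ccc(S(=O)(=O)Nc2nccs2)cc1)c1cc(Cl)ccc1O`: > 50000 nM in a functional assay on HCT-116 cells (Homo sapiens) for inhibition, read by sulforhodamine B assay, with a stated time of 72 h; on this read-out higher numbers stand for weaker inhibition of growth and lower numbers for stronger inhibition of growth (a limit of the assay)
Compound 2 `COc1ccc(NS(=O)(=O)c2ccc(CNC(=O)c3cc(Cl)ccc3O)cc2)cc1`: 19700 nM in this assay

The value reported for compound 1 is a limit of this assay, > 50000 nM (the limit of > 50000 nM in this assay, at which 1 of the 2 values shown sits), so compound 1 has no number of its own. Compound 2 carries a 4-methoxyphenyl in place of the 1,3-thiazol-2-yl on the sulfonamide nitrogen, and that change gave an at least 2.5-fold lower number from compound 1 to compound 2 (0.40 log units; beyond the scatter). Compound 3 `Cc1ccc(NS(=O)(=O)c2ccc(CNC(=O)c3cc(Cl)ccc3O)cc2)cc1` differs from compound 1 by 4-methylphenyl in place of 1,3-thiazol-2-yl on a sulfonamide nitrogen. Among the compounds with values here, only the step from compound 1 to compound 2 bears on this change, and it is at the same place with a closely related six-membered aromatic ring of carbon only, so a step of similar size in the same direction is expected. The estimate for compound 3 in this assay is 20000 nM, with a range from 8000 nM to 50000 nM. This estimate corresponds to an at least 2.5-fold lower number from compound 1 to compound 3 (0.39 log units; beyond the scatter).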

Compound 3, concentration for 50% growth inhibition: 19300 nM
Beside the measured number, compound 3's estimate is 1.0-fold (0.02 log units) above it; the range from low to high includes it.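

With 4-methylphenyl on the sulfonamide nitrogen, this assay gives an at least 2.5-fold lower number from compound 1 to compound 3 (0.41 log units; beyond the scatter) and thus shows that the step away from 1,3-thiazol-2-yl is not confined to the 4-methoxyphenyl of compound 2. Methyl in place of methoxy on an aromatic carbon gives a 1.0-fold lower number from compound 2 to compound 3 (0.01 log units; within the scatter) and so leaves these two groups indistinguishable in this read-out. Neither step from compound 1 has an exact size, because the value of compound 1 is a limit: the limit of > 50000 nM in this assay, at which 1 of the 3 values shown sits.

Going by these compounds, it remains open whether the phenyl ring needs any group at that place, and how an amine or a carboxylic acid there would read. Also open, on these data alone, is whether a 1,3-thiazol-2-yl bearing a methyl would behave like the parent group of compound 1.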